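Urea series: varying the aryl group on the triazole nitrogen

The source may hold more compounds than are shown below. What is called first, only, known or untested is meant among the compounds shown, and "the series" means these compounds.

Three ureas sharing one core have been measured. Compound 1 `O=C(Nc1cccc(OCc2cn(-c3ccccc3)nn2)c1)Nc1ccc(Cl)c(C(F)(F)F)c1` gives 1780 nM in a functional assay on HepG2 cells (Homo sapiens) for inhibition, read by MTT assay, with a stated time of 72 h; a lower number here means a stronger inhibitor, a higher number a weaker inhibitor. Compound 2 `CCc1ccc(-n2cc(COc3cccc(NC(=O)Nc4ccc(Cl)c(C(F)(F)F)c4)c3)nn2)cc1` gives 1950 nM in this assay, and compound 3 `O=C(Nc1cccc(OCc2cn(-c3cccc(C(F)(F)F)c3)nn2)c1)Nc1ccc(Cl)c(C(F)(F)F)c1` gives 1270 nM in this assay. Compound 3 shows the lowest of the three numbers, yet the steps of a 1.4-fold lower number from compound 1 to compound 3 (0.15 log units; within the scatter) and a 1.5-fold lower number from compound 2 to compound 3 (0.19 log units; within the scatter) are both within the scatter, as is a 1.1-fold higher number from compound 1 to compound 2 (0.04 log units; within the scatter), so no ordering among the three can be claimed.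

Compound 4 `COc1ccccc1-n1cc(COc2cccc(NC(=O)Nc3ccc(Cl)c(C(F)(F)F)c3)c2)nn1` has not yet been measured in this assay. It differs from compound 3 only in the aryl group on the ring nitrogen: 2-methoxyphenyl in place of 3-(trifluoromethyl)phenyl on an aromatic nitrogen. Among the measured compounds shown here, the steps that bear on this are a 1.1-fold higher number from compound 1 to compound 2 (0.04 log units; within the scatter), a 1.4-fold lower number from compound 1 to compound 3 (0.15 log units; within the scatter) and a 1.5-fold lower number from compound 2 to compound 3 (0.19 log units; within the scatter), all of which swap groups at the same position and all of which stay within the scatter. On that basis the expected step is a 1.3-fold higher number from compound 3 to compound 4 (0.10 log units; within the scatter), which amounts to no change beyond the scatter. For compound 4 the estimate in this assay is 1600 nM, with a range from 700 nM to 3500 nM.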

Compound 4, half-maximal inhibitory concentration: 11300 nM
Compound 4: middle estimate off by 7.1-fold (0.85 log units), on the low side, outside the stated range (above it).
By their numbers in this assay, from the lowest: compounds 3, 1 and 2 (each within the scatter of the next); then compound 4.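

Among the compounds shown here, the aryl group on the ring nitrogen is not a silent position in this assay: 2-methoxyphenyl in place of 3-(trifluoromethyl)phenyl gives an 8.9-fold higher number from compound 3 to compound 4 (0.95 log units; beyond the scatter) and is a step beyond the scatter, which no step among the earlier compounds was. The other two steps agree, with a 5.8-fold higher number from compound 2 to compound 4 (0.76 log units; beyond the scatter) on replacing 4-ethylphenyl and a 6.3-fold higher number from compound 1 to compound 4 (0.80 log units; beyond the scatter) on putting methoxy in place of hydrogen on the phenyl of compound 1. Phenyl, 4-ethylphenyl and 3-(trifluoromethyl)phenyl give numbers within the scatter of one another, and among the four compounds only 2-methoxyphenyl stands apart from them.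

For the compounds shown here, whether this step follows the methoxy group itself or its place on the ring stays open, and an aryl group carrying an amine or a carboxylic acid has no counterpart here. No data at hand bear on the reason for this step.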